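Longer Alkyl Chain on the Amide Nitrogen: Cytotoxicity Outlook

The compounds below may be only part of what the source reports. "The series", "measured", "known", "first", "only" and "open" are said of these compounds alone.

compound 1, `O=C(/C=C/[C@H]1C[C@@H](O)[C@@H](O)C1)Nc1ccccc1`: in an ADME assay on S2 cells (Drosophila melanogaster) for cytotoxicity, read by MTT assay (a higher number here means that more compound is needed for the effect, a lower number that less compound is needed), compound 1 gives > 200000 nM, which is a limit of the assay.
compound 2, `CCNC(=O)/C=C/[C@H]1C[C@@H](O)[C@@H](O)C1`: in this assay compound 2 gives > 250000 nM, again a limit of the assay.

Compound 2 therefore stands only at a limit, (the limit of > 250000 nM in this assay, at which 1 of the 2 values shown sits). Compound 1 likewise sits at a limit, (the limit of > 200000 nM in this assay, at which 1 of the 2 values shown sits), so the step that the two limits leave unreadable from compound 1 to compound 2 cannot be read. Compound 3, `CCCCNC(=O)/C=C/[C@H]1C[C@@H](O)[C@@H](O)C1`, differs from compound 2 by ethyl in place of hydrogen on a saturated chain carbon, two bonds along the chain from an amide-type nitrogen. No readable measured step bears on this change, so for compound 3 a step of a number no higher from compound 2 to compound 3 (the limit leaves the size open) is expected, that is, nothing beyond the scatter, and the assay is expected to report a limit once more. The estimate for compound 3 is 250000 nM, within 100000 nM to 600000 nM.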

Compound 3, half-maximal effective concentration: > 250000 nM
Compound 3: a limit, no number; the forecaster's own chance of this, stated with the estimate: 80%; the middle value lies on the limit itself.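

In this assay, for the compounds shown here, compound 1, compound 2 and compound 3 all stand at limits, and no step among them can be read. The compounds shown leave open what concentration any of them needs for the effect, and whether the group on the amide nitrogen changes it.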